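Diol variant of compound 2; both parents weakly active

A few compounds are considered here, and "the series" means these few. Any claim that something is new, unique, unknown or untested is made for them only; others in the source may bear on it.

Measured so far:
compound 1, `Oc1nnc(-c2ccccc2)c2cncn12`, gives 19000 nM in a functional assay for inhibition, with Homo sapiens as the target; on this read-out lower numbers stand for stronger inhibition and higher numbers for weaker inhibition.
compound 2, `CCCc1nc(C)c2cnn(CC3CC3)c(=O)n12`, gives > 48000 nM in this assay; this is a limit of the assay and not a number.

Among the measured compounds shown here, compound 1 and compound 2 share no single-point difference, so no step between them can be computed; the two values show only that compound 1 returns a number and compound 2 does not. Compound 2 therefore stands at the limit of this assay, the point at which one of the two values sits (the limit of > 48000 nM in this assay, at which 1 of the 2 values shown sits). Nothing measured in the series gives a size for any step.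

Compound 3, `CCCc1nc(C)c2cnn(CC(O)CO)c(=O)n12`, is built from compound 2 by the change (1,2-dihydroxyethyl in place of cyclopropyl on a saturated chain carbon bound to an aromatic nitrogen), in words 1,2-dihydroxyethyl in place of cyclopropyl on a saturated chain carbon bound to an aromatic nitrogen. With compound 2 already at the limit, no step beyond the scatter can be resolved in either direction; the expectation is that compound 3 also returns no number. Compound 3 is estimated at 60000 nM, range 25000 nM to 150000 nM, which means an expected step that the limit leaves unreadable from compound 2 to compound 3.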

Compound 3, half-maximal inhibitory concentration: > 48000 nM
Compound 3 ended at the assay's limit; the forecaster's own chance of this, stated with the estimate: 80%; the middle value lies beyond the limit too.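

In this assay compound 3 gives > 48000 nM, a limit of the assay and not a number. No step from compound 2 to compound 3 can be read, since both stand at that limit: the limit of > 48000 nM in this assay, at which 2 of the 3 values shown sit.

The compounds shown leave open whether cyclopropylmethyl and 2,3-dihydroxypropyl differ at all in this assay.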